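The source may hold more compounds than are shown below. What is called first, only, known or untested is meant among the compounds shown, and "the series" means these compounds.

Values from a functional assay (mast cells) for inhibition, with Rattus norvegicus as the target; on this read-out higher numbers stand for an effect only at larger amounts of compound and lower numbers for an effect already at smaller amounts
- compound 1 `CC1CC/C(=N\Nc2ccc(F)cc2)c2ncc(C(=O)O)c(=O)n21` gives 1200 nM
- compound 2 `CC1CC/C(=N\Nc2ccc(Br)cc2)c2ncc(C(=O)O)c(=O)n21` gives 2000 nM
- compound 3 `Cc1ccc(N/N=C2\CCC(C)n3c2ncc(C(=O)O)c3=O)cc1` gives 280 nM

Compound 3 stands lowest of the three at 280 nM and so acts at the smallest amount. Compound 4 `CC1CC/C(=N\Nc2ccc(C(=O)O)cc2)c2ncc(C(=O)O)c(=O)n21` keeps the shared core but has carboxy in place of methyl on an aromatic carbon, para to a large group (carboxy in place of methyl on an aromatic carbon). For the measured compounds named here, two measured steps touch this same place. They are a 4.3-fold lower number from compound 1 to compound 3 (0.63 log units; beyond the scatter) and a 7.1-fold lower number from compound 2 to compound 3 (0.85 log units; beyond the scatter) and both are modest. Both end at the methyl compound, so the other two groups tried here gave higher numbers. Going by the values given here, no carboxy compound has been measured, so this offers only a rough guide. The estimated change is a 4.6-fold higher number from compound 3 to compound 4 (0.67 log units; beyond the scatter) in this assay as a modest rise. For compound 4 the estimate is 1300 nM with 350 nM to 5000 nM as the expected range.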

Compound 4, half-maximal effective concentration: 1000000 nM
Compound 4: the middle estimate sits 770-fold (2.89 log units) below what was measured; the whole stated range lies below it.
By their numbers in this assay, from the lowest: compound 3; then compounds 1 and 2 (each within the scatter of the next); then compound 4.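

In this assay, fluoro, bromo and methyl at this position stay within a modest span, but carboxy falls far outside it: a 3600-fold higher number from compound 3 to compound 4 (3.55 log units; beyond the scatter), an 830-fold higher number from compound 1 to compound 4 (2.92 log units; beyond the scatter) and a 500-fold higher number from compound 2 to compound 4 (2.70 log units; beyond the scatter). For the compounds shown here, all three steps are large, so the group at this place can matter far more than the earlier compounds showed. Nothing available here bears on why this happens. Going by these compounds, it remains open whether a methyl ester or an amine at this place would give a number near compound 3 or near compound 4.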